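Swapping the Amino Group of Compound 1 for Methyldisulfanyl

A few compounds are considered here, and "the series" means these few. Any claim that something is new, unique, unknown or untested is made for them only; others in the source may bear on it.

The measured compounds, with their values in a functional assay on EMT6 cells (Mus musculus) for cytotoxicity, with a stated time of 4 h; a higher number here means a weaker inhibitor, a lower number a stronger inhibitor:
Compound 1 `CS(=O)(=O)N1CC(CCl)c2ccc(N)cc21`: 33000 nM
Compound 2 `CN(C)c1ccc2c(c1)N(S(C)(=O)=O)CC2CCl`: 20000 nM
Compound 3 `CSc1ccc2c(c1)N(S(C)(=O)=O)CC2CCl`: a limit of the assay, > 200000 nM

Compound 1 has the highest of the two numbers in this assay; compound 2 stands nearest, and the step of a 1.7-fold lower number from compound 1 to compound 2 (0.22 log units; within the scatter) stays within the scatter, so the two cannot be told apart. The value of compound 3 is not a number but a limit (the limit of > 200000 nM in this assay, at which 1 of the 3 values shown sits).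

Compound 4 `CSSc1ccc2c(c1)N(S(C)(=O)=O)CC2CCl` is not yet measured. It differs from compound 1 in one place: (methylsulfanyl)sulfanyl in place of amino on an aromatic carbon.

Within the data shown here, two measured steps bear on this change, both moving from a nitrogen substituent to a sulfur one on the same aromatic carbon: an at least 6.0-fold higher number from compound 1 to compound 3 (0.78 log units; beyond the scatter) and an at least 10-fold higher number from compound 2 to compound 3 (1.00 log units; beyond the scatter). Both went beyond the scatter toward a weaker inhibitor, and both ended at a limit rather than a number. Since compound 4 also carries a sulfur substituent at that position, a step of similar direction and size is expected in this assay, with a real chance that only a limit is reported again.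

Compound 4 is therefore estimated at 150000 nM, within 40000 nM to 500000 nM, which corresponds to an expected step of a 4.5-fold higher number from compound 1 to compound 4 (0.66 log units; beyond the scatter).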

Compound 4, half-maximal inhibitory concentration: > 50000 nM
Compound 4 ended at the assay's limit; the forecaster's own chance of this, stated with the estimate: 50%; the middle value lies beyond the limit too.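

In this assay compound 4 gives only a limit, not a number, > 50000 nM. With compound 4, both sulfur-linked groups at this aromatic carbon end at limits, while only the nitrogen-linked amino and dimethylamino groups give numbers, and no listed compound goes against this split. Replacing dimethylamino with (methylsulfanyl)sulfanyl gives an at least 2.5-fold higher number from compound 2 to compound 4 (0.39 log units; beyond the scatter), so compound 4 is clearly separated from the dimethylamino compound, whereas replacing amino gives an at least 1.5-fold higher number from compound 1 to compound 4 (0.18 log units; that floor lies within the scatter), so this lower bound alone does not separate it from the amino compound.

Going by these compounds, the step between the two sulfur compounds cannot be read, so the effect of adding a second sulfur to the methylsulfanyl group remains unknown, as does how far either compound lies past its limit. A hydroxyl group or a carboxylic acid on the same aromatic carbon would test whether a measurable number in this assay requires a nitrogen-linked group, or whether the sulfur-linked groups are the exception.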